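This account rests on a few compounds, and the source may have more. Where it says the series, first, only, none or still open, it means among the compounds named here.

- Compound 1 `CCCCCCC#Cc1cc2cn(COCCO)c(=O)nc2o1`: > 50000 nM
- Compound 2 `CCCCCCCCCCCc1cc2cn(COCCO)c(O)nc-2n1`: 41000 nM

Of the compounds shown here, two have been tested in a functional assay on HEL cells (Homo sapiens); on this read-out higher numbers stand for lower toxicity in this test and lower numbers for higher toxicity in this test. Compound 1 gives > 50000 nM, and this value is a limit of the assay and not a number. Its standing is therefore known only as the limit of > 50000 nM in this assay, at which 1 of the 2 values shown sits. Compound 2 gives a number, 41000 nM.

The next compound to be tested is compound 3 `CCCCCCCCC#Cc1cc2cn(COCCO)c(=O)nc2o1`. It departs from compound 1 in one place: ethyl in place of hydrogen on a saturated chain carbon, six bonds along the chain from a triple-bonded carbon. Put another way, the same difference reads propyl to pentyl, and the shared core stays untouched.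

Among the compounds with values here, no measured pair of compounds shows what a change of this kind does in this assay, so the size of the step cannot be read from the data. No shift beyond the usual scatter is expected, and no direction is favoured. Compound 3 may also be reported only as a limit. Stated as an expected step, the estimate is a number no higher from compound 1 to compound 3 (the limit leaves the size open). For compound 3 the estimated value is 50000 nM, with an expected range from 20000 nM to 100000 nM.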

Compound 3, half-maximal cytotoxic concentration: 42000 nM
For compound 3 the middle estimate is 1.2-fold (0.08 log units) above the measured one, and the stated range covers the measured number.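

In this assay, within the data shown here, the change gives the first step at this position, ethyl in place of hydrogen on a saturated chain carbon, six bonds along the chain from a triple-bonded carbon: an at least 1.1-fold lower number from compound 1 to compound 3 (0.07 log units; that floor lies within the scatter). Among these compounds, compound 3 gives a number for this chain, 42000 nM, so the propyl to pentyl difference on the shared core now has one measured end, which the earlier compounds did not provide. The other end remains a limit of the assay and not a number, and that limit belongs to compound 1: the limit of > 50000 nM in this assay, at which 1 of the 3 values shown sits.

As far as these compounds go, the printed floor of the step lies within the scatter, but the true size of the step stays open, so this single pair cannot show whether the change moves the read-out beyond the scatter or how far. Also open, from the compounds shown here alone, is whether a longer chain, or an amine in place of ethyl on this saturated chain carbon, would give a lower number, a higher number or another limit in this assay.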